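The source may report more compounds than this note shows. Statements on the series, on what has been measured and on what is new or still open speak of the compounds shown alone.

Of the compounds shown here, three built on one shared core have been measured in a physicochemical assay, at pH 7.4; on this read-out higher numbers stand for a longer-lived compound and lower numbers for a shorter-lived compound. Compound 1 `CO[C@H]1C(=O)N2C(C(=O)C(C)(C)C)=C(C)[C@@H](OC(C)=O)S(=O)(=O)C12` gives 6.3 h in this assay. Compound 2 `CO[C@H]1C(=O)N2C(C(=O)C(C)(C)C)=C(C)[C@@H](OC(=O)C(C)(C)C)S(=O)(=O)C12` gives 54 h, and compound 3 `CO[C@H]1C(=O)N2C(C(=O)C(C)(C)C)=C(C)[C@@H](OC(=O)c3ccccc3)S(=O)(=O)C12` gives 24 h. Compound 3 therefore holds the second highest number of the three: a 2.3-fold lower number from compound 2 to compound 3 (0.35 log units; beyond the scatter) separates it from compound 2, and a 3.8-fold higher number from compound 1 to compound 3 (0.58 log units; beyond the scatter) separates it from compound 1. For the measured compounds named here, all the measured steps concern only the group on the ester carbonyl, namely an 8.6-fold higher number from compound 1 to compound 2 (0.93 log units; beyond the scatter), a 3.8-fold higher number from compound 1 to compound 3 (0.58 log units; beyond the scatter) and a 2.3-fold lower number from compound 2 to compound 3 (0.35 log units; beyond the scatter). Compound 4 `CO[C@H]1C(=O)N2C(C(=O)C(C)(C)C)=C(C)[C@@H](S(=O)(=O)c3ccccc3)S(=O)(=O)C12` departs differently: phenylsulfonyl in place of benzoyloxy on a saturated ring carbon. Here the ester itself gives way to a sulfone, so no measured step matches this change; the data show only that swapping the acyl group shifts the half-life by modest amounts. An expectation for compound 4 thus rests on little and must carry a wide range. Compound 4 is estimated at 24 h, with a range from 4 h to 150 h, which would mean an expected step of no change at the digits printed from compound 3 to compound 4 (within the scatter).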

Compound 4, half-life: 10 h
Beside the measured number, compound 4's estimate is 2.4-fold (0.38 log units) above it, and the stated range covers the measured number.
By their numbers in this assay, from the lowest: compounds 1 and 4 (each within the scatter of the next); then compound 3; then compound 2.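

Leaving the ester at this saturated ring carbon is a change of its own kind, and even with a phenyl ring present in both groups, phenylsulfonyl gives a shorter half-life than benzoyloxy in this assay (a 2.4-fold lower number from compound 3 to compound 4 (0.38 log units; beyond the scatter)). The drop is larger when phenylsulfonyl replaces ((tert-butyl)carbonyl)oxy (a 5.4-fold lower number from compound 2 to compound 4 (0.73 log units; beyond the scatter)), whereas replacing acetoxy leaves the two compounds within the scatter of each other (a 1.6-fold higher number from compound 1 to compound 4 (0.20 log units; within the scatter)). Thus phenylsulfonyl falls level with the acetoxy ester, below the other two esters, and nothing available here explains that placing.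

Still open, from the compounds shown here alone, is whether methylsulfonyl or tert-butylsulfonyl, in place of phenylsulfonyl, would shift the half-life as the matching acyl changes did among the esters. Also open, going by these compounds, is what an amine or a carboxylic acid at this carbon would give.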